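Fluoro for Chloro at the Far End of the Aryl Ring

The source may report more compounds than this note shows. Statements on the series, on what has been measured and on what is new or still open speak of the compounds shown alone.

Of the compounds shown here, three of one shared core have been measured in a functional assay on the whole organism (strain Swiss) with Mus musculus as the target, in the maximal electroshock model, with a stated time of 0.25 h, at a dose of 100 mg/kg by the intraperitoneal route; on this read-out lower numbers stand for a weaker effect and higher numbers for a stronger effect at the one dose given. Compound 1 `COCC(C(=O)N1CCN(c2cccc(C(F)(F)F)c2)CC1)N1C(=O)CCC1=O` gives 100% in this assay. Compound 2 `CC(C(=O)N1CCN(c2ccccc2)CC1)N1C(=O)CCC1=O` gives 50%, and compound 3 `CC(C(=O)N1CCN(c2ccc(Cl)cc2)CC1)N1C(=O)CCC1=O` gives 50%. Between these two the only difference is chloro in place of hydrogen on an aromatic carbon, and that step, no change at the digits printed from compound 2 to compound 3 (within the scatter), stayed within the scatter. Compound 3 thus stands level with compound 2, the two together forming the lowest pair of the three numbers, while compound 1, with its 100%, lies beyond the scatter above them; compound 1 differs from compound 3 in more than one place, so its gap says nothing about any single change.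

Compound 4 `CC(C(=O)N1CCN(c2ccc(F)cc2)CC1)N1C(=O)CCC1=O` has not yet been measured in this assay. It differs from compound 3 by fluoro in place of chloro on an aromatic carbon. Within the data shown here, the one step that bears on this exchange is the one from hydrogen to chloro at the same place, which produced no change; a swap of one halogen for another at that place is therefore expected to leave the read-out essentially where it is, with an expected step of no change at the digits printed from compound 3 to compound 4 (within the scatter) in this assay. Compound 4 is accordingly estimated at 50%, in a range from 25% to 75%.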

Compound 4, a percentage reported as activity, at one dose (the size of the read-out at that dose, not a potency): 75%
Estimate against measurement, compound 4: 25 percentage points below; measured number inside the range.
By their numbers in this assay, from the lowest: compounds 2 and 3 (each within the scatter of the next); then compound 4; then compound 1.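

At the place para to a large group, the identity of the halogen now matters in this assay: fluoro in place of chloro gives a number 25 percentage points higher from compound 3 to compound 4 (beyond the scatter), so the two are not interchangeable there. Fluoro in place of hydrogen at the same place gives a number 25 percentage points higher from compound 2 to compound 4 (beyond the scatter), while the earlier step for chloro in place of hydrogen was no change at the digits printed from compound 2 to compound 3 (within the scatter), so that flat step holds for chloro and cannot be taken as a rule for every substituent at this place. Both new steps are modest and rest on a read-out at a single dose, so they show a difference in the size of the effect at that dose and say nothing of potency.

The compounds shown leave open whether bromo, a methoxy group or an amine at this place would read like fluoro, like chloro or like neither. They also leave open whether the gain seen with 4-fluorophenyl would carry over to the core of compound 1, which differs from compound 4 in more than one place and so cannot be compared with it directly. No measurement at hand speaks to why fluoro and chloro part here.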